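Compound 2 to compound 3: a 3,5-dimethylpiperazin-1-yl swap

A few compounds are considered here, and "the series" means these few. Any claim that something is new, unique, unknown or untested is made for them only; others in the source may bear on it.

In an ADME assay on microsomes from liver (Rattus norvegicus) for metabolic stability, read by LC-MS, using NADPH, with a stated time of 60 min, tested at 0.1 uM (a lower number here means that less of the compound is left, a higher number that more of the compound is left), compound 2 (`O=C(c1ccnc(Nc2nc3cnc(Nc4ccc(F)c(C(F)(F)F)c4)cc3[nH]2)c1)N1CCN(C2CC2)CC1`) stands at 53%, the lower of the two measured numbers, and compound 1 (`Fc1ccc(Nc2cc3[nH]c(Nc4cc(N5CCNCC5)ccn4)nc3cn2)cc1C(F)(F)F`) gives 73%. Going by the values given here, compound 3 (`C[C@@H]1CN(C(=O)c2ccnc(Nc3nc4cnc(Nc5ccc(F)c(C(F)(F)F)c5)cc4[nH]3)c2)C[C@H](C)N1`) has no measurement yet. The change is 3,5-dimethylpiperazin-1-yl in place of 4-cyclopropylpiperazin-1-yl on a carbonyl carbon, with 3,5-dimethylpiperazin-1-yl in place of 4-cyclopropylpiperazin-1-yl on a carbonyl carbon. Among the compounds with values here, only one measured step bears on it: a number 20 percentage points lower from compound 1 to compound 2 (beyond the scatter), a modest step with (4-cyclopropylpiperazin-1-yl)carbonyl in place of piperazin-1-yl on an aromatic carbon. Within the data shown here, that step does not separate the carbonyl from the cyclopropyl, and no measured compound carries 3,5-dimethylpiperazin-1-yl. The step expected here is therefore small and tentative in direction, a number 9 percentage points higher from compound 2 to compound 3 (within the scatter). For compound 3 the estimated value is 62%, with an expected range of 42% to 80%.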

Compound 3, percent of the compound remaining: 90%
Beside the measured number, compound 3's estimate is 28 percentage points below it; the whole stated range lies below it.
By their numbers in this assay, from the lowest: compound 2; then compound 1; then compound 3.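

In this assay, the group on the carbonyl carbon strongly affects the percent remaining: 3,5-dimethylpiperazin-1-yl in place of 4-cyclopropylpiperazin-1-yl gives a clear gain (a number 37 percentage points higher from compound 2 to compound 3 (beyond the scatter)). The carbonyl-linked group need not bring the loss seen for compound 2, as the (3,5-dimethylpiperazin-1-yl)carbonyl group reverses the direction of that earlier step (a number 17 percentage points higher from compound 1 to compound 3 (beyond the scatter)). Nothing available explains either step.

The change removes the cyclopropyl group, adds two methyl groups with defined stereocentres and adds a hydrogen-bond donor, so the compounds shown do not assign the gain to any one of these differences. Plain piperazin-1-yl or 4-methylpiperazin-1-yl on the same carbonyl carbon would help to separate them, and the stereoisomers of the 3,5-dimethylpiperazin-1-yl group remain open.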